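The source may report more compounds than this note shows. Statements on the series, on what has been measured and on what is new or still open speak of the compounds shown alone.

Measured so far in a functional assay on MCF7 cells (Homo sapiens) for antiproliferative activity, read by CCK-8 assay, with a stated time of 72 h; a lower number here means a stronger inhibitor, a higher number a weaker inhibitor:
compound 1 `COc1ccc(C(=O)Nc2cccc(-c3oc4cc(-c5ccc(F)cc5)ccc4c(=O)c3O)c2)cc1` gives 6250 nM;
compound 2 `O=C(Nc1cccc(-c2oc3cc(-c4ccc(F)cc4)ccc3c(=O)c2O)c1)c1ccc(Br)cc1` gives 24000 nM;
compound 3 `Cc1cc(C(=O)Nc2cccc(-c3oc4cc(-c5ccc(F)cc5)ccc4c(=O)c3O)c2)ccc1F` gives 7710 nM.

Compound 1 has the lowest number of the three, though compound 3 lies within the scatter of it, while compound 2 stands clearly higher. Compound 4 `CCCc1ccc(C(=O)Nc2cccc(-c3oc4cc(-c5ccc(F)cc5)ccc4c(=O)c3O)c2)cc1` has not been measured; it differs from compound 1 in one place: propyl in place of methoxy on an aromatic carbon. For the measured compounds named here, two measured steps bear on this. The step of a 3.8-fold higher number from compound 1 to compound 2 (0.58 log units; beyond the scatter) changes the same aromatic carbon, swapping methoxy for bromo, and gave a modestly higher number. The step of a 1.2-fold higher number from compound 1 to compound 3 (0.09 log units; within the scatter) alters the same six-membered aromatic ring of carbon only in another way and stayed within the scatter. Going by the values given here, a propyl group has not been tried here, so the guide is rough: the one change at the same place raised the number modestly, the other hardly moved it. A small to modest rise in this assay is therefore expected, a 1.8-fold higher number from compound 1 to compound 4 (0.25 log units; within the scatter). Compound 4 is estimated at 11000 nM, with a likely range from 4500 nM to 27000 nM.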

Compound 4, half-maximal inhibitory concentration: 36800 nM
Estimate against measurement, compound 4: 3.3-fold (0.52 log units) below; the whole stated range lies below it.
By their numbers in this assay, from the lowest: compounds 1 and 3 (each within the scatter of the next); then compounds 2 and 4 (each within the scatter of the next).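

In this assay, swapping methoxy for propyl on this aromatic carbon gives a 5.9-fold higher number from compound 1 to compound 4 (0.77 log units; beyond the scatter), while replacing bromo with propyl at the same place gives a 1.5-fold higher number from compound 2 to compound 4 (0.19 log units; within the scatter), so propyl and bromo cannot be told apart here. Against the 4-fluoro-3-methylphenyl amide, the 4-propylphenyl amide gives a 4.8-fold higher number from compound 3 to compound 4 (0.68 log units; beyond the scatter), which places compound 4 with compound 2 in the higher pair and leaves compounds 1 and 3 in the lower pair. No available evidence explains why these groups separate in this way.

The compounds shown leave open whether an ethyl group, a longer chain such as pentyl, or a dimethylamino group on this carbon would fall with the lower pair or the higher pair. They also leave open whether the same order would hold if the 4-fluorophenyl group on the shared core were changed.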